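Swapping the Sulfonyl for a Carbonyl in Compound 1

The compounds below may be only part of what the source reports. "The series", "measured", "known", "first", "only" and "open" are said of these compounds alone.

Compound 1 `COc1cc(N(Cc2nc3ccccc3[nH]2)S(=O)(=O)c2ccc(Br)cc2)cc(OC)c1OC` gives the lowest of the three numbers in a functional assay on MGC-803 cells (Homo sapiens) for inhibition, read by MTT assay, with a stated time of 48 h (a higher number here means a weaker inhibitor, a lower number a stronger inhibitor), at 2190 nM. Compound 2 `COc1cc(N(Cc2nc3ccccc3[nH]2)S(=O)(=O)c2ccc(C(C)(C)C)cc2)cc(OC)c1OC` gives 24100 nM, and compound 3 `COc1ccc(S(=O)(=O)N(Cc2nc3ccccc3[nH]2)c2cc(OC)c(OC)c(OC)c2)cc1OC` gives 22500 nM. The steps of an 11-fold higher number from compound 1 to compound 2 (1.04 log units; beyond the scatter) and a 10-fold higher number from compound 1 to compound 3 (1.01 log units; beyond the scatter) both alter the ring carried on the sulfonyl sulfur. Compound 4 `COc1cc(N(Cc2nc3ccccc3[nH]2)C(=O)c2ccc(Br)cc2)cc(OC)c1OC` differs from compound 1 in another way: (4-bromophenyl)carbonyl in place of (4-bromophenyl)sulfonyl on a nitrogen on an aromatic ring. For the measured compounds named here, no measured step replaces the sulfonyl itself, so the size of this change in this assay cannot be read from the measured compounds, and only a modest step, if any beyond the scatter, is expected, more likely toward a higher number. Compound 4 is therefore estimated at 4500 nM, within 1000 nM to 20000 nM, which is expected to be a 2.1-fold higher number from compound 1 to compound 4 (0.31 log units; beyond the scatter).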

Compound 4, half-maximal inhibitory concentration: 14600 nM
The estimate for compound 4 lay 3.2-fold (0.51 log units) below the measured number; the measured number falls inside the stated range.
By their numbers in this assay, from the lowest: compound 1; then compounds 4, 3 and 2 (each within the scatter of the next).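

In this assay, the link to the ring proves to matter as well as the ring itself: with the 4-bromophenyl kept, (4-bromophenyl)carbonyl in place of (4-bromophenyl)sulfonyl gives a 6.7-fold higher number from compound 1 to compound 4 (0.82 log units; beyond the scatter). The earlier steps shown here changed only the ring on the sulfonyl sulfur, so they could not show this. No measurement at hand gives a reason for this step. Still open, from the compounds shown here alone, is whether the carbonyl has a similar effect with the 4-(tert-butyl)phenyl or 3,4-dimethoxyphenyl ring, and how a plain methylene would compare in that place.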